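Methoxy Addition on a Dihydrochalcone-Type Phenol Series

This account rests on a few compounds, and the source may have more. Where it says the series, first, only, none or still open, it means among the compounds named here.

Measured so far:
- compound 1, `COc1cc(C(=O)/C=C/c2cccc(OC)c2OC)ccc1O`: 67.8%
- compound 2, `COc1ccc(CCCc2ccc(OC)c(OC)c2)c(O)c1`: 88.9%

In an ADME assay on RAW264.7 cells (Mus musculus) for cytotoxicity, read by MTT assay, with a stated time of 24 h, tested at 5 ug/mL (a lower number here means a stronger effect, a higher number a weaker effect of the compound at the concentration tested), compound 1 gives 67.8%. In this assay compound 2 gives 88.9%, the higher of the two numbers; the gap to compound 1 lies beyond the scatter. Among the measured compounds shown here, no step between compounds differing in one place is available, so the effect of a single change is not yet known.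

Compound 3, `COc1ccc(CCCc2ccc(OC)c(OC)c2OC)c(O)c1`, is next to be measured in this assay. It differs from compound 2 by methoxy in place of hydrogen on an aromatic carbon. Because compound 2 already gives 88.9%, a weak effect, the expected step of a number 3.9 percentage points lower from compound 2 to compound 3 (within the scatter) is small, probably within the scatter, with a slight lean toward a lower number. Compound 3 is estimated at 85%, within 70% to 98%.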

Compound 3, a percentage reported as activity, at one concentration (the size of the read-out at that concentration, not a potency): 84.5%
The estimate for compound 3 lay 0.5 percentage points above the measured number, within the range that was stated.
By their numbers in this assay, from the lowest: compound 1; then compounds 3 and 2 (each within the scatter of the next).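

Among the compounds shown here, the first step in one place in this assay is a number 4.4 percentage points lower from compound 2 to compound 3 (within the scatter) and so gives the series its first reading of a single change. Methoxy in place of hydrogen on an aromatic carbon, at this place ortho to a large group and ortho to a methoxy group, gives compound 3 a read-out that cannot be told apart from that of compound 2. Nothing measured here speaks to a cause for this step.

From the compounds shown here alone, whether an amine, a carboxylic acid or a longer alkoxy chain at the same place would also leave the read-out within the scatter stays open. Also open, going by these compounds, is whether the same methoxy change would give a step of similar size on the core of compound 1.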